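The compounds below may be only part of what the source reports. "The series", "measured", "known", "first", "only" and "open" are said of these compounds alone.

Measured compounds and values:

- compound 1, `Brc1ccc(C(c2ccccc2)N2CCN(c3ncnc4c3cnn4-c3ccccc3)CC2)cc1`: in a functional assay on cells (Rhabdomyosarcoma cell, Homo sapiens) for cytotoxicity (on this read-out higher numbers stand for weaker inhibition and lower numbers for stronger inhibition), compound 1 gives > 25000 nM, which is a limit of the assay rather than a number.
- compound 2, `N#Cc1cccc(C(c2ccccc2)N2CCN(c3ncnc4c3cnn4-c3ccccc3)CC2)c1`: in this assay compound 2 gives > 25000 nM, again a limit.
- compound 3, `c1ccc(C(c2ccncc2)N2CCN(c3ncnc4c3cnn4-c3ccccc3)CC2)cc1`: in this assay compound 3 gives > 25000 nM, also a limit.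

Compound 3 thus stands where every measured compound stands, namely at the limit of > 25000 nM in this assay, at which 3 of the 3 values shown sit. The three steps among them, a step that the two limits leave unreadable from compound 1 to compound 2, a step that the two limits leave unreadable from compound 1 to compound 3 and a step that the two limits leave unreadable from compound 2 to compound 3, are all unreadable, since both ends of each sit at the limit.

Compound 4, `c1ccc(C(c2cccnc2)N2CCN(c3ncnc4c3cnn4-c3ccccc3)CC2)cc1`, differs from compound 3 in one place: pyridin-3-yl in place of pyridin-4-yl on a saturated chain carbon bound to an amine nitrogen in a ring and an aromatic carbon. Going by the values given here, no measured step bears on this change in a readable way, so no direction can be taken from the data. What the data do show is that three different aryl groups at this position all leave cytotoxicity below the reach of the assay, and a shift of the nitrogen within the same ring is a small change against that background. The step that the limit leaves unreadable from compound 3 to compound 4 is therefore expected to stay within the scatter. Compound 4 is estimated at 35000 nM, with a range from 15000 nM to 100000 nM, and most likely it will again return only a limit.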

Compound 4, half-maximal inhibitory concentration: > 25000 nM
Compound 4: no number, only a limit; the forecaster's own chance of this, stated with the estimate: 85%; the middle value is on the limit's open side.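

Compound 4 also gives only a limit, so none of its steps to compound 1, compound 2 or compound 3 can be read: the limit of > 25000 nM in this assay, at which 4 of the 4 values shown sit.

The compounds shown leave open whether changing the aryl group at this place alters the result in this assay at all.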